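A few compounds are considered here, and "the series" means these few. Any claim that something is new, unique, unknown or untested is made for them only; others in the source may bear on it.

Values in a functional assay on L929 cells (Mus musculus) for inhibition; a lower number here means a stronger inhibitor of growth, a higher number a weaker inhibitor of growth:
- compound 1 `Nc1nn2c(O)cc(CCl)nc2c1[N+](=O)[O-]`: > 50 ug/mL (a limit)
- compound 2 `NNCc1cc(O)n2nc(N)c([N+](=O)[O-])c2n1`: 35.2 ug/mL
- compound 3 `Nc1nn2c(O)cc(CNNc3ccc(F)cc3)nc2c1[N+](=O)[O-]`: 41.4 ug/mL

In this assay compound 3 gives 41.4 ug/mL, within the scatter of compound 2 at 35.2 ug/mL. Compound 1 reports only a limit, > 50 ug/mL.

Compound 4 `Nc1nn2c(O)cc(CNCCO)nc2c1[N+](=O)[O-]` carries 2-hydroxyethyl in place of (4-fluorophenyl)amino on an amine nitrogen. Two measured changes bear on this. Aminoamino in place of chloro gave an at least 1.4-fold lower number from compound 1 to compound 2 (0.15 log units; that floor lies within the scatter), and 4-fluorophenyl in place of hydrogen gave a 1.2-fold higher number from compound 2 to compound 3 (0.07 log units; within the scatter). Neither shows a change beyond the scatter, so none is expected here either. The expected step is a 1.0-fold lower number from compound 3 to compound 4 (0.01 log units; within the scatter). For compound 4 the estimate is 40 ug/mL, with an expected range from 20 ug/mL to 70 ug/mL.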

Compound 4, concentration for 50% growth inhibition: > 50 ug/mL
Compound 4 gave a limit, no number; the forecaster's own chance of this, stated with the estimate: 35%; at least 1.2-fold (0.09 log units) between middle value and limit.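

On this amine nitrogen, in this assay, a 2-hydroxyethyl chain with no ring gives an at least 1.2-fold higher number from compound 3 to compound 4 (0.08 log units; that floor lies within the scatter), and also an at least 1.4-fold higher number from compound 2 to compound 4 (0.15 log units; that floor lies within the scatter). Compound 4 gives only a limit, > 50 ug/mL, so this change brings no gain in growth inhibition at this position, and its true size stays hidden: the limit of > 50 ug/mL in this assay, at which 2 of the 4 values shown sit.

The step from compound 1 to compound 4 cannot be read. Still open, going by these compounds, is whether a longer chain or a carboxylic acid on this nitrogen would give a measured number rather than a limit.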